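The source may report more compounds than this note shows. Statements on the series, on what has been measured and on what is new or still open speak of the compounds shown alone.

Working notes on the series, measured so far in a functional assay on UACC-62 cells (Homo sapiens) for cytotoxicity, read by sulforhodamine B assay; on this read-out higher numbers stand for weaker inhibition of growth and lower numbers for stronger inhibition of growth:

- compound 1 `COc1ccc(/C=N\NC(=S)NC(C)(C)CCC[C@](C)(O)[C@@H]2CC=C(C)CC2)cc1`: 22100 nM
- compound 2 `CC1=CC[C@@H]([C@@](C)(O)CCCC(C)(C)NC(=S)N/N=C\c2ccc(N(C)C)cc2)CC1`: > 100000 nM
- compound 3 `CC1=CC[C@@H]([C@@](C)(O)CCCC(C)(C)NC(=S)N/N=C\c2ccc([N+](=O)[O-])cc2)CC1`: 62200 nM

The entry for compound 2, > 100000 nM, is a limit of the assay and not a number. Of the two true numbers, compound 3 has the higher, and the nearest is compound 1, as shown by a 2.8-fold higher number from compound 1 to compound 3 (0.45 log units; beyond the scatter).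

Next is compound 4 `CC1=CC[C@@H]([C@@](C)(O)CCCC(C)(C)NC(=S)N/N=C\c2cccc(Cl)c2)CC1`, described by 3-chlorophenyl in place of 4-nitrophenyl on a carbon with a double bond to nitrogen. The measured steps bear on this only indirectly, as none involves 3-chlorophenyl. Nitro in place of methoxy gave a 2.8-fold higher number from compound 1 to compound 3 (0.45 log units; beyond the scatter), nitro in place of dimethylamino gave an at least 1.6-fold lower number from compound 2 to compound 3 (0.20 log units; that floor lies within the scatter), and dimethylamino in place of methoxy gave an at least 4.5-fold higher number from compound 1 to compound 2 (0.65 log units; beyond the scatter). The group on the aromatic ring therefore matters in this assay, but these steps give no direction for chlorine. A small drift towards compound 1 is the working expectation, not a step beyond the scatter. The expected move is a 1.6-fold lower number from compound 3 to compound 4 (0.19 log units; within the scatter). For compound 4 the estimated value is 40000 nM, with an expected range from 14000 nM to 100000 nM.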

Compound 4, concentration for total growth inhibition: 18100 nM
Compound 4: the middle estimate sits 2.2-fold (0.34 log units) above what was measured; the range from low to high includes it.
By their numbers in this assay, from the lowest: compounds 4 and 1 (each within the scatter of the next); then compound 3. At a limit, above all of these: compound 2.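

In this assay, 3-chlorophenyl in place of 4-nitrophenyl on the carbon with a double bond to nitrogen gives a 3.4-fold lower number from compound 3 to compound 4 (0.54 log units; beyond the scatter), and against 4-methoxyphenyl the same group gives a 1.2-fold lower number from compound 1 to compound 4 (0.09 log units; within the scatter), so a ring carrying chlorine fits at this position and matches the best number seen so far without moving past it. Against 4-(dimethylamino)phenyl it gives an at least 5.5-fold lower number from compound 2 to compound 4 (0.74 log units; beyond the scatter), which is a floor and not a measured size. The entry for compound 2 is a limit of the assay and not a number: the limit of > 100000 nM in this assay, at which 1 of the 4 values shown sits.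

On these data alone, whether a fluorine, a bromine or a carboxylic acid in place of the chlorine would keep the number near that of compound 4 remains open. All four compounds share one core, so the data shown say nothing about changes elsewhere in the structure.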